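The compounds below may be only part of what the source reports. "The series", "measured", "known", "first", "only" and "open" are said of these compounds alone.

Measured in a functional assay on the whole organism for antagonist activity, with Mus musculus as the target; a lower number here means that less compound is needed, a higher number that more compound is needed for the effect:
- Compound 1 `COC(=O)N(C)CC#CCn1ccnc1`: > 100 mg/kg (a limit, not a number)
- Compound 2 `COC(=O)N(C)CC#CCn1cncc1C`: 3 mg/kg
- Compound 3 `COC(=O)N(C)C(C)C#CCn1cncc1C`: 3.7 mg/kg

Compound 2 stands at the low end of these numbers, together with compound 3, and the two lie within the scatter of each other: a 1.2-fold higher number from compound 2 to compound 3 (0.09 log units; within the scatter).

Compound 4 `CCOC(=O)N(C)CC#CCn1cncc1C` changes compound 2 in one place, turning methoxycarbonyl into ethoxycarbonyl: methyl in place of hydrogen on a saturated chain carbon bound to an oxygen next to a carbonyl group. Going by the values given here, no measured step touches this place. Methyl on an aromatic carbon gave a large step, an at least 33-fold lower number from compound 1 to compound 2 (1.52 log units; beyond the scatter). The closer case is methyl on a saturated chain carbon, although at a different site, and that gave a 1.2-fold higher number from compound 2 to compound 3 (0.09 log units; within the scatter). On that basis, little change is expected in this assay, and the estimated step is a 1.5-fold higher number from compound 2 to compound 4 (0.18 log units; within the scatter). The expected value for compound 4 is 4.5 mg/kg, with an estimated range from 1.5 mg/kg to 14 mg/kg.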

Compound 4, dose for half-maximal effect: 66 mg/kg
Beside the measured number, compound 4's estimate is 15-fold (1.17 log units) below it; measured number above the stated range.
By their numbers in this assay, from the lowest: compounds 2 and 3 (each within the scatter of the next); then compound 4. At a limit, above all of these: compound 1.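

In this assay, turning methoxycarbonyl into ethoxycarbonyl gives a 22-fold higher number from compound 2 to compound 4 (1.34 log units; beyond the scatter), so this position responds strongly to one added methyl, while the methyl on the other chain carbon left compound 3 within the scatter of compound 2. A small addition to a saturated chain carbon can therefore matter greatly or hardly at all, depending on the site. Nothing shown here accounts for this step. Still open, on these data alone, is whether a longer chain, such as propoxycarbonyl, raises the number further. Also open, as far as these compounds go, is whether an amine in place of the methoxy group keeps the low number of compound 2.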